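Notes on the step from compound 3 to compound 4

The source may hold more compounds than are shown below. What is called first, only, known or untested is meant among the compounds shown, and "the series" means these compounds.

In a functional assay on MCF7 cells (Homo sapiens) for antiproliferative activity, read by MTT assay, with a stated time of 72 h (on this read-out higher numbers stand for weaker inhibition and lower numbers for stronger inhibition), compound 1 `CC1=CC[C@H]2[C@H](CC[C@]2(C)O)C(C)(C)[C@@H]1CC[C@H]1[C@]2(C)CC[C@H](OC(=O)CCC(=O)O)C(C)(C)O[C@H]2CC[C@@]1(C)O` reaches only a limit of the assay, > 50000 nM. Compound 2 `CC1=CC[C@H]2[C@H](CC[C@]2(C)O)C(C)(C)[C@@H]1CC[C@H]1[C@]2(C)CC[C@H](OC(=O)c3ccc(Cl)cc3)C(C)(C)O[C@H]2CC[C@@]1(C)O` gives 24100 nM and compound 3 `CC1=CC[C@H]2[C@H](CC[C@]2(C)O)C(C)(C)[C@@H]1CC[C@H]1[C@]2(C)CC[C@H](OC(=O)c3ccc(F)cc3)C(C)(C)O[C@H]2CC[C@@]1(C)O` gives 33500 nM. These two values cannot be separated, as a 1.4-fold higher number from compound 2 to compound 3 (0.14 log units; within the scatter) lies within the scatter. Against the limit, an at least 2.0-fold lower number from compound 1 to compound 2 (0.31 log units; beyond the scatter) is beyond the scatter, whereas an at least 1.4-fold lower number from compound 1 to compound 3 (0.17 log units; that floor lies within the scatter) has a floor within it.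

Compound 4 `CC1=CC[C@H]2[C@H](CC[C@]2(C)O)C(C)(C)[C@@H]1CC[C@H]1[C@]2(C)CC[C@H](OC(=O)c3ccc(Cl)c(Cl)c3)C(C)(C)O[C@H]2CC[C@@]1(C)O` carries 3,4-dichlorophenyl in place of 4-fluorophenyl on a carbonyl carbon. The closest measured change is the halogen swap between compound 2 and compound 3, a 1.4-fold higher number from compound 2 to compound 3 (0.14 log units; within the scatter). For the measured compounds named here, it gives only a faint lean towards a lower number for a chlorine-bearing ester, and no measured compound shows the effect of a second chlorine. The expected change is therefore small, near the edge of the scatter: a 1.6-fold lower number from compound 3 to compound 4 (0.20 log units; within the scatter). For compound 4 the estimated value is 21000 nM, with an expected range of 9000 nM to 42000 nM.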

Compound 4, half-maximal inhibitory concentration: 11900 nM
Estimate against measurement, compound 4: 1.8-fold (0.25 log units) above, and the stated range covers the measured number.
By their numbers in this assay, from the lowest: compound 4; then compounds 2 and 3 (each within the scatter of the next). At a limit, above all of these: compound 1.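

In this assay, this ester position now separates aromatic groups, which the earlier halogen swap did not do: 3,4-dichlorophenyl in place of 4-fluorophenyl on the carbonyl carbon gives a 2.8-fold lower number from compound 3 to compound 4 (0.45 log units; beyond the scatter) in a single change. Chloro in place of hydrogen on an aromatic carbon also counts on its own, with a 2.0-fold lower number from compound 2 to compound 4 (0.31 log units; beyond the scatter) as the step, so the further chlorine moves the number beyond the scatter. Against the 2-carboxyethyl ester the result is only a floor, an at least 4.2-fold lower number from compound 1 to compound 4 (0.62 log units; beyond the scatter) being read against a limit: the limit of > 50000 nM in this assay, at which 1 of the 4 values shown sits.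

Open, on these data alone, is whether this step belongs to chlorine itself or would also follow from bromo, methoxy or trifluoromethyl on the aromatic ring. Also open, as far as these compounds go, is whether an amide in place of the ester link would keep the step.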